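The compounds below may be only part of what the source reports. "The series", "measured", "known", "first", "only" and "open" are said of these compounds alone.

Measured compounds: compound 1 `CC(C)Oc1ccc(NC(=O)CSc2nnc(Cc3nn(C)c(=O)c4ccccc34)n2C)cc1`; compound 2 `Cn1c(Cc2nn(C)c(=O)c3ccccc23)nnc1SCCCCCCCCCCC(=O)Nc1ccc(Cl)cc1`; compound 3 `Cn1c(Cc2nn(C)c(=O)c3ccccc23)nnc1SCCCCCC(=O)Nc1ccc(Cl)cc1Cl`.

In an assay on isolated protein (Mus musculus) for inhibition of IL15-IL15 receptor (Homo sapiens), read by resazurin assay, with stated times of 30 min and 2.5 days (a lower number here means a stronger inhibitor, a higher number a weaker inhibitor), compound 1 gives > 30000 nM, which is a limit of the assay and not a number (the limit of > 30000 nM in this assay, at which 1 of the 3 values shown sits). Compound 2 gives 20000 nM in this assay. Compound 3 gives 4100 nM, the lowest of the two numbers shown, and its gap to compound 2 lies beyond the scatter. Compound 4 `Cn1c(Cc2nn(C)c(=O)c3ccccc23)nnc1SCCCCCCCC(=O)Nc1ccc(I)cc1` has not been measured; it differs from compound 3 by 2-((4-iodophenyl)carbamoyl)ethyl in place of (2,4-dichlorophenyl)carbamoyl on a saturated chain carbon, five bonds along the chain from a sulfur. Within the data shown here, no measured pair isolates this change. Since compound 2 at 20000 nM sits well above compound 3 at 4100 nM, a weakening step beyond the scatter is expected in this assay. The step of a 2.4-fold higher number from compound 3 to compound 4 (0.39 log units; beyond the scatter) is the expected outcome. Compound 4 is estimated at 10000 nM, range 3500 nM to 30000 nM.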

Compound 4, half-maximal inhibitory concentration: 1300 nM
Compound 4: the middle estimate sits 7.7-fold (0.89 log units) above what was measured; measured number outside the range, below it.
By their numbers in this assay, from the lowest: compound 4; then compound 3; then compound 2. At a limit, above all of these: compound 1.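

In this assay, 2-((4-iodophenyl)carbamoyl)ethyl in place of (2,4-dichlorophenyl)carbamoyl on a saturated chain carbon, five bonds along the chain from a sulfur, gives a 3.2-fold lower number from compound 3 to compound 4 (0.50 log units; beyond the scatter). Among these compounds, this is the first step read, and it shows that this position tolerates this exchange with a modest gain rather than a loss. Nothing measured here bears on the reason for the step. The change alters the chain and the ring substituents together, so their shares cannot be separated. As far as these compounds go, a carboxylic acid or an amine at the chain end, or a longer chain carrying the same iodophenyl group, remains open.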